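Adding one methyl to the but-1-en-1-yl group

A few compounds are considered here, and "the series" means these few. Any claim that something is new, unique, unknown or untested is made for them only; others in the source may bear on it.

Measured in a functional assay on A549 cells (Homo sapiens) for inhibition, read by MTT assay, with a stated time of 72 h (on this read-out higher numbers stand for weaker inhibition and lower numbers for stronger inhibition), so far
Compound 1 `C=C(Cl)C(=O)Nc1cc(Nc2nc3c(c(-c4cn(C)c5ccc(F)cc45)n2)CSCC3)c(OC)cc1N(C)CCN(C)C` gives 864 nM
Compound 2 `COc1cc(N(C)CCN(C)C)c(NC(=O)C=C(C)C)cc1Nc1nc2c(c(-c3cn(C)c4ccc(F)cc34)n1)CSCC2` gives 902 nM
Compound 3 `CC/C=C\C(=O)Nc1cc(Nc2nc3c(c(-c4cn(C)c5ccc(F)cc45)n2)CSCC3)c(OC)cc1N(C)CCN(C)C` gives 1450 nM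

Compound 3, at 1450 nM, is not separated from the other two compounds: a 1.6-fold higher number from compound 2 to compound 3 (0.21 log units; within the scatter) and a 1.7-fold higher number from compound 1 to compound 3 (0.22 log units; within the scatter) both lie within the scatter, as does a 1.0-fold higher number from compound 1 to compound 2 (0.02 log units; within the scatter). Compound 4 `COc1cc(N(C)CCN(C)C)c(NC(=O)/C=C\C(C)C)cc1Nc1nc2c(c(-c3cn(C)c4ccc(F)cc34)n1)CSCC2` differs from compound 3 by methyl in place of hydrogen on a saturated chain carbon bound to a double-bonded chain carbon and a saturated chain carbon, which turns but-1-en-1-yl into 3-methylbut-1-en-1-yl. Among the compounds with values here, the three exchanges on the carbonyl carbon are the steps that bear on this. Since even a 1.7-fold higher number from compound 1 to compound 3 (0.22 log units; within the scatter) stays within the scatter, no shift beyond the scatter is expected for compound 4 in this assay, in either direction. The expected result is a 1.2-fold lower number from compound 3 to compound 4 (0.06 log units; within the scatter). Compound 4 is estimated at 1250 nM, with an expected range from 550 nM to 2800 nM.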

Compound 4, half-maximal inhibitory concentration: 1150 nM
Estimate against measurement, compound 4: 1.1-fold (0.04 log units) above; low and high end bracket the measured number.
By their numbers in this assay, from the lowest: compounds 1, 2, 4 and 3 (each within the scatter of the next).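

In this assay, the change from ethyl to isopropyl within the group on the carbonyl carbon gives a 1.3-fold lower number from compound 3 to compound 4 (0.10 log units; within the scatter), so this saturated chain carbon carries a methyl in place of hydrogen with no shift beyond the scatter. The 3-methylbut-1-en-1-yl group also stays level with the other two groups at that carbonyl carbon, with a 1.3-fold higher number from compound 2 to compound 4 (0.11 log units; within the scatter) and a 1.3-fold higher number from compound 1 to compound 4 (0.12 log units; within the scatter). No supporting measurement is available to explain these small steps. The compounds shown leave open whether a larger group on this carbon, such as an amine, a carboxylic acid or a longer chain, would move the number beyond the scatter.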